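An untested stereoisomer of a heptyl compound

The source may hold more compounds than are shown below. What is called first, only, known or untested is meant among the compounds shown, and "the series" means these compounds.

Measured so far in a functional assay on EC9706 cells (Homo sapiens) for antiproliferative activity, read by MTT assay, with a stated time of 48 h; a higher number here means a weaker inhibitor, a lower number a stronger inhibitor:
- compound 1 `CCCCCCCn1cc(COC[C@@H]2OC[C@H](N)[C@@H]2O)nn1` gives > 128000 nM (a limit)
- compound 2 `CCCCCCCCCCn1cc(COC[C@@H]2OC[C@H](N)[C@@H]2O)nn1` gives 15600 nM

In this assay compound 1 stands at > 128000 nM which is a limit and not a number. Compound 3 `CCCCCCCn1cc(COC[C@@H]2OC[C@H](N)[C@H]2O)nn1` is the next case. Its change is the two compounds have the same atoms and bonds and differ only in configuration as drawn: 1 of 3 stereo elements differ; a stereocentre at a saturated ring carbon is drawn S in compound 1 and R in compound 3 and a stereocentre at a saturated ring carbon is drawn S in compound 1 and R in compound 3. Going by the values given here, the only measured step is an at least 8.2-fold lower number from compound 1 to compound 2 (0.91 log units; beyond the scatter) and it lies beyond the scatter, but it alters the chain and no stereocentre, so it sets no size for this change. The expected step is a number no higher from compound 1 to compound 3 (the limit leaves the size open) in no set direction and none beyond the scatter. For compound 3 the estimate is 128000 nM with an expected range from 50000 nM to 300000 nM in this assay as the read-out.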

Compound 3, half-maximal inhibitory concentration: > 128000 nM
Compound 3 ended at the assay's limit (the forecaster's own chance of this, stated with the estimate: 70%); the middle value lies on the limit itself.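

No step can be read between compound 1 and compound 3, since each stands at a limit of this assay and not at a number: the limit of > 128000 nM in this assay, at which 2 of the 3 values shown sit.

The compounds shown leave open whether the saturated ring carbon drawn S in compound 1 and R in compound 3 changes the result in this assay at all.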